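This account rests on a few compounds, and the source may have more. Where it says the series, first, only, none or still open, it means among the compounds named here.

Working notes on the series. Compound 1 `O=C(CN1N=C(C2CCCCC2)c2ccccc2N(CC(=O)C2CCCC2)C1=O)Nc1cccc(C(=O)O)c1` gives 1.95 nM in a functional assay on stomach for antagonist activity at Gastrin/cholecystokinin type B receptor (Rattus norvegicus); a higher number here means weaker binding, a lower number tighter binding; among the three measured compounds it stands second highest. Compound 3 `CC(C)(C)C(=O)CN1C(=O)N(CC(=O)Nc2ccc3ccn(CC(=O)O)c3c2)N=C(C2CCCCC2)c2ccccc21` gives 0.851 nM, the nearest value, and compound 2 `CC(C)(C)C(=O)CN1C(=O)N(CC(=O)Nc2cccc(CCC(=O)O)c2)N=C(C2CCCCC2)c2ccccc21` gives 4.47 nM, the furthest, each lying beyond the scatter from compound 1. Compound 4 `O=C(O)CSc1cccc(NC(=O)CN2N=C(C3CCCCC3)c3ccccc3N(CC(=O)C3CCCC3)C2=O)c1` is not yet measured. It differs from compound 1 in one place: (carboxymethyl)sulfanyl in place of carboxy on an aromatic carbon, on an aromatic carbon of a six-membered aromatic ring of carbon only, meta to a large group. Going by the values given here, no single-change pair among the measured compounds covers this change. Compound 2 carries a longer acid chain and stays near compound 1, so a small step is expected, weakening or none beyond the scatter, with a 1.8-fold higher number from compound 1 to compound 4 (0.25 log units; within the scatter). Compound 4 is estimated at 3.5 nM, within 1.2 nM to 10 nM.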

Compound 4, dissociation constant: 1.48 nM
Compound 4: middle estimate off by 2.4-fold (0.37 log units), on the high side; the range from low to high includes it.
By their numbers in this assay, from the lowest: compounds 3, 4 and 1 (each within the scatter of the next, the first and the last beyond it); then compound 2.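

In this assay, (carboxymethyl)sulfanyl in place of carboxy on an aromatic carbon is a 1.3-fold lower number from compound 1 to compound 4 (0.12 log units; within the scatter) and so stays within the scatter. Going by these compounds alone, this is the first single-change step, and it shows that this position accepts a group of 5 heavy atoms, sulfur included, in place of one of 3 without a readable shift. No measurement on hand accounts for the two groups reading alike. On these data alone, whether a methyl ester, a primary amide or a chain with oxygen in place of sulfur would hold this level at the same position stays open.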